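Replacing the benzyl ester of compound 1 with a methanesulfonamide

A few compounds are considered here, and "the series" means these few. Any claim that something is new, unique, unknown or untested is made for them only; others in the source may bear on it.

Measured compounds:
Compound 1 `O=C(OCc1ccccc1)C1(S(=O)(=O)c2ccc(Oc3ccc(OC(F)(F)F)cc3)cc2)CCC2(CCNCC2)C1`: > 15000 nM
Compound 2 `O=C1CN(C(=O)C2(S(=O)(=O)c3ccc(Oc4ccc(OC(F)(F)F)cc4)cc3)CCC3(CCNCC3)C2)CCN1`: 7500 nM
Compound 3 `CN(C)S(=O)(=O)NC(=O)C1(S(=O)(=O)c2ccc(Oc3ccc(OC(F)(F)F)cc3)cc2)CCC2(CCNCC2)C1`: > 15000 nM

In a functional assay on blood (Homo sapiens), with a stated time of 60 min, in the presence of a further agent that is not named here (a lower number here means that less compound is needed, a higher number that more compound is needed for the effect), compound 1 gives > 15000 nM, which is a limit of the assay rather than a number. Compound 1 therefore stands only at a limit, and it shares that position with one other compound, namely (the limit of > 15000 nM in this assay, at which 2 of the 3 values shown sit). Compound 2 carries a 3-oxopiperazin-1-yl group on the carbonyl carbon and gives 7500 nM; the step is an at least 2.0-fold lower number from compound 1 to compound 2 (0.30 log units; that floor lies within the scatter). In this assay compound 3 gives > 15000 nM, again a limit. Compound 4 `CS(=O)(=O)NC(=O)C1(S(=O)(=O)c2ccc(Oc3ccc(OC(F)(F)F)cc3)cc2)CCC2(CCNCC2)C1` differs from compound 1 by methanesulfonamido in place of benzyloxy on a carbonyl carbon.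

For the measured compounds named here, the steps that bear on this change are a step that the two limits leave unreadable from compound 1 to compound 3 and an at least 2.0-fold higher number from compound 2 to compound 3 (0.30 log units; that floor lies within the scatter), since compound 3 carries the closest relative of the methanesulfonamido group. Neither measured acylsulfonamide-type compound reached a number, so the expected step of a number no higher from compound 1 to compound 4 (the limit leaves the size open) is none beyond the scatter. Compound 4 is expected to give about 15000 nM, within 7000 nM to 40000 nM, because a step that the two limits leave unreadable from compound 1 to compound 3 left both ends at the limit.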

Compound 4, half-maximal effective concentration: > 15000 nM
Compound 4 was reported as a limit; the forecaster's own chance of this, stated with the estimate: 70%; the middle value sits exactly at the limit.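

In this assay, methanesulfonamido on the carbonyl carbon leaves compound 4 with compounds 1 and 3, at a limit of the assay and not at a number: the limit of > 15000 nM in this assay, at which 3 of the 4 values shown sit. The steps among these three compounds cannot be read, including the change from dimethylamino to methyl on the sulfonyl sulfur. For the compounds shown here, compound 2 is the only compound here with a number, and the one readable step is an at least 2.0-fold higher number from compound 2 to compound 4 (0.30 log units; that floor lies within the scatter).

The limits leave open where compounds 1, 3 and 4 would actually fall, and whether they differ from one another at all. Also open, on these data alone, is how this assay would read with a hydroxyl group on the same carbonyl carbon, giving a carboxylic acid, or with a simple amine forming an amide there.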